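The source may report more compounds than this note shows. Statements on the series, on what has been measured and on what is new or still open speak of the compounds shown alone.

Measured compounds in the series:

Compound 1, `Cc1nc(S(C)(=O)=O)ccc1Oc1ncnc(OC2CCN(C(=O)OC(C)(C)C#N)CC2)c1F`: 1320 nM in a functional assay on isolated protein for inhibition of Glucose-dependent insulinotropic receptor (Rattus norvegicus), read by HTRF and cAMP accumulation; on this read-out higher numbers stand for an effect only at larger amounts of compound and lower numbers for an effect already at smaller amounts
Compound 2, `Cc1nc(S(C)(=O)=O)ccc1Oc1ncnc(OC2CCN(C(=O)O[C@H](C)C(F)(F)F)CC2)c1F`: 110 nM in this assay
Compound 3, `CCC(F)(F)C(=O)N1CCC(Oc2ncnc(Oc3ccc(S(C)(=O)=O)nc3C)c2F)CC1`: 69.2 nM in this assay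

Compound 2 gives the second highest of the three numbers. Its nearest neighbour is compound 3, where the step of a 1.6-fold lower number from compound 2 to compound 3 (0.20 log units; within the scatter) stays within the scatter, so the two cannot be ordered. Its furthest is compound 1, where the step of a 12-fold lower number from compound 1 to compound 2 (1.08 log units; beyond the scatter) is large and clearly beyond the scatter.

The next compound, compound 4, `Cc1nc(S(C)(=O)=O)ccc1Oc1ncnc(OC2CCN(C(=O)C3(F)CCC3)CC2)c1F`, differs from compound 2 at the carbonyl carbon:

a group of 5 heavy atoms (4 carbon, 1 fluorine; one four-membered non-aromatic ring of carbon only) in place of a group of 7 heavy atoms (3 carbon, 1 oxygen, 3 fluorine; no ring), on a carbonyl carbon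

Among the measured compounds shown here, two measured steps bear on this change. Both convert the carbamate-type oxygen substituent into a fluorinated carbon substituent on the carbonyl carbon: a 1.6-fold lower number from compound 2 to compound 3 (0.20 log units; within the scatter), which is within the scatter, and a 19-fold lower number from compound 1 to compound 3 (1.28 log units; beyond the scatter), which is large but starts from the much higher number of compound 1. Starting from compound 2, therefore, no step beyond the scatter is expected in this assay for compound 4; if anything, a slightly lower number, in line with compound 3.

The estimate for compound 4 in this assay is 80 nM, with a range of 30 nM to 250 nM, corresponding to an expected step of a 1.4-fold lower number from compound 2 to compound 4 (0.14 log units; within the scatter).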

Compound 4, half-maximal effective concentration: 123 nM
Compound 4: middle estimate off by 1.5-fold (0.19 log units), on the low side, and the stated range covers the measured number.
By their numbers in this assay, from the lowest: compounds 3, 2 and 4 (each within the scatter of the next); then compound 1.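

In this assay, the carbonyl carbon also accepts a group with one four-membered non-aromatic ring of carbon only and a fluorine: replacing 1-(trifluoromethyl)ethoxy gives a 1.1-fold higher number from compound 2 to compound 4 (0.05 log units; within the scatter), and replacing the open 1,1-difluoropropyl gives a 1.8-fold higher number from compound 3 to compound 4 (0.25 log units; within the scatter). Compound 2, compound 3 and compound 4 therefore cannot be ordered, even though the group on the carbonyl carbon is linked through oxygen in compound 2, is an open chain in compound 3 and holds a ring in compound 4; among the four compounds, only compound 1, with its 1-cyano-1-methylethyl group and no fluorine, stands apart, at an 11-fold lower number from compound 1 to compound 4 (1.03 log units; beyond the scatter). No measurement is available that would explain why these three different groups give numbers within the scatter of one another.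

The compounds shown leave open whether the fluorine on the ring matters, which a plain cyclobutyl on the carbonyl carbon would address. Going by these compounds, how far the ring can grow also remains open, as a cyclopentyl or cyclohexyl group at this place would show.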